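A few compounds are considered here, and "the series" means these few. Any claim that something is new, unique, unknown or untested is made for them only; others in the source may bear on it.

Measured compounds in a functional assay on A549 cells (Homo sapiens) for antiproliferative activity, read by CCK-8 assay, with a stated time of 72 h; on this read-out lower numbers stand for stronger inhibition and higher numbers for weaker inhibition:
- compound 1, `CC1=NN(c2ccc(C)cc2)C(=O)C12C=CC(=O)C=C2c1cccc(C)c1`: 22500 nM
- compound 2, `CC1=NN(c2ccc(C)cc2)C(=O)C12C=CC(=O)C=C2c1ccccc1`: 46300 nM
- compound 3, `CC1=NN(c2ccc(Cl)cc2)C(=O)C12C=CC(=O)C=C2c1ccccc1`: > 100000 nM

Compound 2 gives 46300 nM in this assay. Compound 1 gives 22500 nM. The step between them is a 2.1-fold lower number from compound 2 to compound 1 (0.31 log units; beyond the scatter), and the change is methyl in place of hydrogen on an aromatic carbon. For compound 3 the result is only a limit, > 100000 nM, which is the limit of the assay and not a number (the limit of > 100000 nM in this assay, at which 1 of the 3 values shown sits). The two cores, that of compound 2 and that of compound 3, differ by chloro in place of methyl on an aromatic carbon, a step of an at least 2.1-fold higher number from compound 2 to compound 3 (0.33 log units; beyond the scatter).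

Compound 4, `CC1=NN(c2ccc(Cl)cc2)C(=O)C12C=CC(=O)C=C2c1ccc(C)cc1`, is not yet measured. It differs from compound 3 by methyl in place of hydrogen on an aromatic carbon. This is the same kind of change as from compound 2 to compound 1, though not the same: in compound 1 the methyl sits meta to a large group, in compound 4 it sits para to a large group. Against a limit, the expected step is an at least 1.1-fold lower number from compound 3 to compound 4 (0.04 log units; that floor lies within the scatter), resting only on the modest gain seen in a 2.1-fold lower number from compound 2 to compound 1 (0.31 log units; beyond the scatter) and on the unknown true value of compound 3. Compound 4 is thus estimated at 90000 nM, with a range from 30000 nM to 300000 nM, and there is a real chance that this assay again reports only a limit for compound 4.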

Compound 4, half-maximal inhibitory concentration: 33400 nM
The estimate for compound 4 lay 2.7-fold (0.43 log units) above the measured number, and the stated range covers the measured number.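

In this assay, methyl in place of hydrogen on an aromatic carbon gives a lower number on both cores, and the new step (an at least 2.9-fold lower number from compound 3 to compound 4 (0.47 log units; beyond the scatter)) points the same way as the earlier one (a 2.1-fold lower number from compound 2 to compound 1 (0.31 log units; beyond the scatter)). The direction of the change therefore carries from the core of compound 2 to the core of compound 3, while the relative size of the two steps stays unresolved: the same change on two cores in this assay, a 2.1-fold lower number (0.31 log units; beyond the scatter) from compound 2 to compound 1 and an at least 2.9-fold lower number (0.47 log units; beyond the scatter) from compound 3 to compound 4; the limit leaves it open whether they differ. The comparison also does not isolate the effect of the core, as the methyl of compound 4 sits para to a large group and the methyl of compound 1 sits at a different place on the ring, and the value of compound 3 is only a limit: the limit of > 100000 nM in this assay, at which 1 of the 4 values shown sits.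

The compounds shown leave open whether 4-methylphenyl gives a similar step on the core of compound 2, and whether the methyl gives the same result at other places on the ring within a single core. They also leave open how a longer chain such as ethyl, a methoxy group, an amine or a carboxylic acid would read in this assay at the place the methyl occupies.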